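The source may report more compounds than this note shows. Statements on the series, on what has been measured and on what is new or still open speak of the compounds shown alone.

Among the compounds with values here, in a functional assay on DU-145 cells (Homo sapiens) for inhibition, read by trypan blue exclusion, with a stated time of 96 h (a lower number here means a stronger inhibitor of growth, a higher number a weaker inhibitor of growth), compound 2 `O=C(O)c1ccc(C(=O)/C(=C\c2ccc(Cl)c([N+](=O)[O-])c2)SCc2ccc(Br)cc2)cc1` gives 500 nM and compound 1 `O=C(O)c1ccc(C(=O)/C(=C\c2ccc(Cl)c([N+](=O)[O-])c2)SCc2ccc(F)cc2)cc1` gives 1000 nM, two values within the scatter of each other at the low end of the numbers so far, whereas compound 3 `CSc1ccc(/C=C(/SCc2ccc(Br)cc2)C(=O)c2ccc(C(=O)O)cc2)cc1` gives 10000 nM. Compound 4 `Cc1ccc(CS/C(=C/c2ccc(Cl)c([N+](=O)[O-])c2)C(=O)c2ccc(C(=O)O)cc2)cc1` has methyl in place of bromo on an aromatic carbon, para to a large group: methyl in place of bromo on an aromatic carbon. The closest measured change swaps that same substituent, bromo in place of fluoro, and it is small: a 2.0-fold lower number from compound 1 to compound 2 (0.30 log units; within the scatter). The large step, a 20-fold higher number from compound 2 to compound 3 (1.30 log units; beyond the scatter), alters a different part of the structure, which compound 4 leaves unchanged. No step beyond the scatter is therefore expected in this assay. The estimated step is a 1.4-fold higher number from compound 2 to compound 4 (0.15 log units; within the scatter). For compound 4 the expected value is 700 nM, with an estimated range of 250 nM to 2000 nM.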

Compound 4, concentration for 50% growth inhibition: 1000 nM
For compound 4 the middle estimate is 1.4-fold (0.15 log units) below the measured one; low and high end bracket the measured number.
By their numbers in this assay, from the lowest: compounds 2, 1 and 4 (each within the scatter of the next); then compound 3.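

In this assay, a group other than a halogen now stands at this position, and methyl stays within the scatter of both bromo (a 2.0-fold higher number from compound 2 to compound 4 (0.30 log units; within the scatter)) and fluoro (no change at the digits printed from compound 1 to compound 4 (within the scatter)). Across fluoro, bromo and methyl, this position has therefore shown no step beyond the scatter. Nothing measured here explains this result. On these data alone, it remains open whether an amine, a hydroxyl or a carboxylic acid at this position, or a longer chain such as butyl, would also stay within the scatter.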